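Amide substituent change and cytotoxicity in a short series

A few compounds are considered here, and "the series" means these few. Any claim that something is new, unique, unknown or untested is made for them only; others in the source may bear on it.

Measured so far:
- compound 1 `O=C(NC1CC1)c1c(NO)cc(-c2ccc(Cl)cc2)oc1=O`: in an ADME assay on Huh-7 cells (Homo sapiens) for cytotoxicity, with a stated time of 3 days (on this read-out lower numbers stand for higher toxicity in this test and higher numbers for lower toxicity in this test), compound 1 gives 12800 nM
- compound 2 `O=C(Nc1ccccc1)c1c(NO)cc(-c2cccs2)oc1=O`: in this assay compound 2 gives only a limit, > 20000 nM
- compound 3 `O=C(Nc1ccc(Cl)cc1)c1c(NO)cc(-c2cccs2)oc1=O`: in this assay compound 3 gives only a limit, > 20000 nM

Compound 3 sits at the limit of > 20000 nM in this assay, at which 2 of the 3 values shown sit, so its place among the three is known only as a limit. Going by the values given here, the one measured step that involves it, a step that the two limits leave unreadable from compound 2 to compound 3, starts and ends at that limit and carries no readable size. Among the compounds with values here, compound 1, which differs from compound 3 in more than one place, is the only compound with a numeric value in this assay , and no single step links it to compound 3.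

Compound 4 `Cc1ccccc1NC(=O)c1c(NO)cc(-c2cccs2)oc1=O` differs from compound 3 by 2-methylphenyl in place of 4-chlorophenyl on an amide-type nitrogen. Within the data shown here, no measured step bears directly on this change. Among the measured compounds shown here, with compound 3 at a limit and the only adjacent step unreadable, the expectation is a step of a number no higher from compound 3 to compound 4 (the limit leaves the size open) of no readable size, and compound 4 is estimated at 20000 nM, within 8000 nM to 40000 nM, most likely reported again as a limit.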

Compound 4, half-maximal cytotoxic concentration: > 20000 nM
Compound 4: only a limit was reported; the forecaster's own chance of this, stated with the estimate: 60%; the middle value sits exactly at the limit.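

No new step can be read for compound 4 against compound 2 or compound 3, as each gives only a limit in this assay: the limit of > 20000 nM in this assay, at which 3 of the 4 values shown sit.

From the compounds shown here alone, whether any change on the amide-type nitrogen alters the read-out in this assay stays open, as does how compound 1 relates to the others through a single change.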